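A few compounds are considered here, and "the series" means these few. Any claim that something is new, unique, unknown or untested is made for them only; others in the source may bear on it.

In a functional assay on NCI-H460 cells (Homo sapiens) for inhibition, read by MTT assay, with a stated time of 72 h (a higher number here means a weaker inhibitor, a lower number a stronger inhibitor), compound 1 `O=C1Nc2ccccc2/C1=C\C(=O)c1cccc(Cl)c1` gives 9800 nM. Among the measured compounds shown here, the only other measured compound, compound 2 `O=C1Nc2ccccc2/C1=C\C(=O)c1cc(F)cc(F)c1`, gives 13300 nM. These two numbers lie within the scatter of each other, so neither compound can be ranked over the other. Compound 3 `CCC(=O)Nc1cccc(C(=O)/C=C2/C(=O)Nc3ccccc32)c1` keeps the core of compound 1 but carries propanoylamino in place of chloro on an aromatic carbon, meta to a large group: propanoylamino in place of chloro on an aromatic carbon. For the measured compounds named here, no measured pair tests such a swap, so the data give only a weak guide, namely the narrow gap between compound 1 at 9800 nM and compound 2 at 13300 nM. In this assay, a step no larger than the scatter is therefore expected, with no firm direction. The estimated step is a 1.1-fold lower number from compound 1 to compound 3 (0.04 log units; within the scatter). The estimate for compound 3 is 9000 nM, with an expected range of 3000 nM to 27000 nM.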

Compound 3, half-maximal inhibitory concentration: 10300 nM
Estimate against measurement, compound 3: 1.1-fold (0.06 log units) below; measured number inside the range.
By their numbers in this assay, from the lowest: compounds 1, 3 and 2 (each within the scatter of the next).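

Replacing chloro with propanoylamino on this aromatic carbon, meta to a large group, gives a 1.1-fold higher number from compound 1 to compound 3 (0.02 log units; within the scatter) in this assay. A single chlorine atom can therefore give way to a group of 5 heavy atoms, with 1 hydrogen-bond donor and 1 hydrogen-bond acceptor, and the read-out shows no difference beyond the scatter. No measured evidence is at hand to explain why these two groups give such similar numbers.

Still open, as far as these compounds go, is how an amine, a carboxylic acid or a longer chain than propanoylamino would fare at this position. Also open, from the compounds shown here alone, is whether any group here can move the number beyond the scatter: compound 1, compound 3 and compound 2 each lie within the scatter of the next.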